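A few compounds are considered here, and "the series" means these few. Any claim that something is new, unique, unknown or untested is made for them only; others in the source may bear on it.

Of the compounds shown here, three with one shared core have been tested for how much of each is needed to harm liver-derived cells. In an ADME assay on HepG2 cells (Homo sapiens) for cytotoxicity (a higher number here means that more compound is needed for the effect, a lower number that less compound is needed), compound 1 `Cc1ccc(S(=O)(=O)N[C@@H](CC(=O)NC(C)(C)C)C(=O)NCCNS(=O)(=O)c2ccccc2)cc1` gives > 11000 nM, which is a limit of the assay and not a number. Compound 2 `Cc1ccc(S(=O)(=O)N[C@@H](CC(=O)NC(C)(C)C)C(=O)NCCNC(=O)c2cc(Cl)ccc2Cl)cc1` gives > 11000 nM, again a limit rather than a number. Compound 3 `Cc1ccc(S(=O)(=O)N[C@@H](CC(=O)NC(C)(C)C)C(=O)NCCNC(=O)c2ccccc2F)cc1` gives > 11000 nM, once more a limit and not a number. So compound 3 stands where all three stand, at the point described by the limit of > 11000 nM in this assay, at which 3 of the 3 values shown sit, and none of the three is separated from the others by a readable step.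

Compound 4 `COc1cc(OC)cc(C(=O)NCCNC(=O)[C@H](CC(=O)NC(C)(C)C)NS(=O)(=O)c2ccc(C)cc2)c1` differs from compound 3 by 3,5-dimethoxyphenyl in place of 2-fluorophenyl on a carbonyl carbon. The step most like this one, at the same carbonyl carbon, is a step that the two limits leave unreadable from compound 2 to compound 3; the two other measured steps, a step that the two limits leave unreadable from compound 1 to compound 2 and a step that the two limits leave unreadable from compound 1 to compound 3, are likewise unreadable because every value sits at the limit in the limit of > 11000 nM in this assay, at which 3 of the 3 values shown sit. Within the data shown here, no measured step therefore points in either direction, and the expectation for compound 4 is a step that the limit leaves unreadable from compound 3 to compound 4, that is, no change beyond the scatter. Compound 4 is expected to give 15000 nM, within a range from 7000 nM to 40000 nM, most probably reported again only as a limit.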

Compound 4, half-maximal effective concentration: > 11000 nM
Compound 4 ended at the assay's limit; the forecaster's own chance of this, stated with the estimate: 85%; the middle value is on the limit's open side.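

In this assay compound 4 gives > 11000 nM, which is a limit and not a number. No step linking compound 4 with compound 1, compound 2 or compound 3 can be read, and all four compounds stay at one point: the limit of > 11000 nM in this assay, at which 4 of the 4 values shown sit.

The compounds shown leave open how much of each is needed to harm the cells, and whether any of these changes alters that amount.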